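A few compounds are considered here, and "the series" means these few. Any claim that something is new, unique, unknown or untested is made for them only; others in the source may bear on it.

Measured compounds in a functional assay on Rec1 cells (Homo sapiens) for inhibition, read by luminescence and CellTiter-Glo, with a stated time of 72 h; on this read-out lower numbers stand for stronger inhibition and higher numbers for weaker inhibition:

Compound 1 `C/C=C/C(=O)Nc1ccc(Cn2nc(-c3ccc(Oc4ccccc4)cc3)cc2C(=O)O)cc1` gives 23600 nM.
Compound 2 `C/C=C/C(=O)Nc1ccc(Cn2nc(-c3ccc(Oc4ccccc4)cc3)cc2CO)cc1` gives 12200 nM.
Compound 3 `C/C=C/C(=O)N1CCCC(n2nc(-c3ccc(Oc4ccccc4)cc3)cc2C(=O)O)C1` gives 31000 nM.

Compound 1 and compound 2 differ in one place, (hydroxymethyl in place of carboxy on an aromatic carbon), and the step in this assay was a 1.9-fold lower number from compound 1 to compound 2 (0.29 log units; within the scatter). Compound 3 carries a different core from compound 1; how the two cores differ is not broken down here, and the two values of compound 1 and compound 3 lie within the scatter of each other, so they show no separation in this assay.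

Compound 4 `C/C=C/C(=O)N1CCCC(n2nc(-c3ccc(Oc4ccccc4)cc3)cc2CO)C1` is not yet measured. It differs from compound 3 by hydroxymethyl in place of carboxy on an aromatic carbon, the same change as that from compound 1 to compound 2, at a place described in the same words. For the measured compounds named here, as the one earlier step was within the scatter, the expected step in this assay is a 1.9-fold lower number from compound 3 to compound 4 (0.29 log units; within the scatter), resting on the single pair compound 1 and compound 2 and on the value of compound 3.

Compound 4 is estimated at 16000 nM, with an expected range from 7000 nM to 36000 nM.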

Compound 4, half-maximal inhibitory concentration: 27200 nM
The estimate for compound 4 lay 1.7-fold (0.23 log units) below the measured number; the measured number falls inside the stated range.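

In this assay, for the compounds shown here, hydroxymethyl in place of carboxy on an aromatic carbon gives a 1.1-fold lower number from compound 3 to compound 4 (0.06 log units; within the scatter), so on the core of compound 3 this change again produces no step that can be read. Set beside the earlier step, the result shows no difference between the two cores: the same change on two cores in this assay, a 1.9-fold lower number (0.29 log units; within the scatter) from compound 1 to compound 2 and a 1.1-fold lower number (0.06 log units; within the scatter) from compound 3 to compound 4, 1.7-fold (0.23 log units) apart, within the scatter of two such steps. The change therefore behaves alike on these two cores in that neither step leaves the scatter, but this does not show a real gain in inhibition from the change on either core, and two pairs say nothing about any further core.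

The compounds shown leave open whether another group at this place, such as an amine, a primary carboxamide or a longer chain ending in hydroxyl, would move the number beyond the scatter. They also leave open whether such a group would then act alike on both cores, which only a step larger than the scatter could test.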